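Trading a Phenethyl Arm for a Hydroxyethyl Amide

The source may report more compounds than this note shows. Statements on the series, on what has been measured and on what is new or still open speak of the compounds shown alone.

Three compounds have been measured in an ADME assay on HOS cells (Homo sapiens) for cytotoxicity, read by luminescence and ATP content, with a stated time of 48 h; a higher number here means that more compound is tolerated, a lower number that less compound is tolerated:
compound 1 `COc1ccc2c(O)c(C(=O)NCc3ccc(F)cc3F)c(=O)n(O)c2n1`, compound 1 gives 12000 nM
compound 2 `Nc1c(C(=O)NCc2ccc(F)cc2F)c(=O)n(O)c2ncc(CCCCCCOCc3ccccc3)cc12`, compound 2 gives 14400 nM
compound 3 `Nc1c(C(=O)NCc2ccc(F)cc2F)c(=O)n(O)c2ncc(CCc3ccccc3)cc12`, compound 3 gives 18000 nM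

The value of compound 3 lies within the usual scatter of both compound 2 and compound 1, so the three are not told apart. Compound 4 `Nc1c(C(=O)NCc2ccc(F)cc2F)c(=O)n(O)c2ncc(/C=C/C(=O)NCCO)cc12` is built from compound 3 by the change (2-((2-hydroxyethyl)carbamoyl)ethenyl in place of phenethyl on an aromatic carbon). Among the measured compounds shown here, the only measured step that bears on it is a 1.3-fold higher number from compound 2 to compound 3 (0.10 log units; within the scatter), where phenyl replaced 4-(benzyloxy)butyl on the same arm; that step did not move the number beyond the scatter. With only that to go on, compound 4 is expected to sit near compound 3, with a step of no change at the digits printed from compound 3 to compound 4 (within the scatter), giving an estimate of 18000 nM within 8000 nM to 40000 nM.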

Compound 4, half-maximal cytotoxic concentration: > 250000 nM
Compound 4: no number, only a limit (the forecaster's own chance of this, stated with the estimate: 25%); at least 13-fold (1.14 log units) between middle value and limit.
By their numbers in this assay, from the lowest: compounds 1, 2 and 3 (each within the scatter of the next). At a limit, above all of these: compound 4.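

This position is not indifferent to what it carries: the swap of phenethyl for 2-((2-hydroxyethyl)carbamoyl)ethenyl gives an at least 13-fold higher number from compound 3 to compound 4 (1.14 log units; beyond the scatter), whereas the other change on this arm, a 1.3-fold higher number from compound 2 to compound 3 (0.10 log units; within the scatter), does not leave the scatter. In this assay compound 4 gives > 250000 nM, which is a limit of the assay and not a number. The entering arm has no ring and carries hydrogen-bond donors and acceptors, while phenethyl has an aromatic ring and neither.

Which part of the new arm matters remains open, since the ethenyl link, the amide and the terminal hydroxyl all arrive together. A saturated ethyl link to the same amide, or a carboxylic acid or amine ending the arm, would help separate them.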